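The source may report more compounds than this note shows. Statements on the series, on what has been measured and on what is new or still open speak of the compounds shown alone.

Measured compounds and their numbers:

- Compound 1 `CC(C)COc1nc(C(C)(C)C)ccc1CNC(=O)C(C)c1ccc(NS(C)(=O)=O)c(F)c1`: 0.6 nM
- Compound 2 `COCCCOc1nc(C(C)(C)C)ccc1CNC(=O)C(C)c1ccc(NS(C)(=O)=O)c(F)c1`: 5.6 nM
- Compound 3 `CC(C(=O)NCc1ccc(C(C)(C)C)nc1OCc1ccccc1)c1ccc(NS(C)(=O)=O)c(F)c1`: 4.4 nM

In an assay on cells for antagonist activity at transient receptor potential cation channel subfamily V member 1 (Homo sapiens), read by FLIPR and calcium flux, with a stated time of 6 min (a higher number here means a weaker inhibitor, a lower number a stronger inhibitor), compound 1 gives 0.6 nM. Compound 2 in this assay gives 5.6 nM, and compound 3 gives 4.4 nM. Of the three, compound 3 has the second-highest number; one of its steps is within the scatter (a 1.3-fold lower number from compound 2 to compound 3 (0.10 log units; within the scatter)) and the other is well beyond it (a 7.3-fold higher number from compound 1 to compound 3 (0.87 log units; beyond the scatter)).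

Compound 4 `CCCCSc1nc(C(C)(C)C)ccc1CNC(=O)C(C)c1ccc(NS(C)(=O)=O)c(F)c1` is not yet measured. Relative to compound 3 the change is butylsulfanyl in place of benzyloxy on an aromatic carbon. Going by the values given here, the steps measured so far, a 9.3-fold higher number from compound 1 to compound 2 (0.97 log units; beyond the scatter) and a 7.3-fold higher number from compound 1 to compound 3 (0.87 log units; beyond the scatter), both alter the group on the saturated carbon bound to the ring oxygen while keeping that oxygen; the move to compound 4 replaces the whole benzyloxy group with butylsulfanyl, so no measured step maps onto it directly. What the data do show is that compound 1, bearing a short branched alkyl ether, gives 0.6 nM, the lowest number of the set, and compound 4 carries a short alkyl chain as well. A modest downward step is therefore expected, with wide uncertainty. For compound 4 the estimated number in this assay is 1.5 nM (range 0.4 nM to 6 nM), an expected step of a 2.9-fold lower number from compound 3 to compound 4 (0.47 log units; beyond the scatter).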

Compound 4, inhibition constant: 3.2 nM
Beside the measured number, compound 4's estimate is 2.1-fold (0.33 log units) below it, and the stated range covers the measured number.
By their numbers in this assay, from the lowest: compound 1; then compounds 4, 3 and 2 (each within the scatter of the next).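

In this assay, going by these compounds alone, butylsulfanyl on the aromatic carbon next to the ring nitrogen is the first group here attached through sulfur rather than oxygen, and the steps from the two ether comparators remain within the scatter: a 1.4-fold lower number from compound 3 to compound 4 (0.14 log units; within the scatter) and a 1.8-fold lower number from compound 2 to compound 4 (0.24 log units; within the scatter). At this position, therefore, benzyloxy, 3-methoxypropoxy and butylsulfanyl cannot be told apart in this assay, despite the loss of the ring and the oxygen link on going to butylsulfanyl. Isobutoxy stays separate, with a 5.3-fold higher number from compound 1 to compound 4 (0.73 log units; beyond the scatter), so a short alkyl chain on this carbon does not by itself match compound 1, and no measurement given here accounts for that gap.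

This step changes both the linking atom and the shape of the chain, so the data cannot assign the gap to sulfur or to the loss of branching, a question that butoxy and isobutylsulfanyl at the same place would separate. Also open, on these data alone, is how a nitrogen link, as in a butylamino group, or a longer chain such as hexylsulfanyl would read in this assay.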